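Amide to Urea on a Methoxy-Chlorophenyl Core

A few compounds are considered here, and "the series" means these few. Any claim that something is new, unique, unknown or untested is made for them only; others in the source may bear on it.

Compound 1 `COc1cc(-c2nn(-c3cccc(NC(=O)c4ccc(Cl)c(C(F)(F)F)c4)c3)cc2-c2ccncc2)ccc1Cl` carries a 4-chloro-3-(trifluoromethyl)phenyl amide on its shared core. In a functional assay on HCC 2998 cells (Homo sapiens) for inhibition, read by sulforhodamine B assay, with a stated time of 48 h (a lower number here means a stronger inhibitor of growth, a higher number a weaker inhibitor of growth), compound 1 gives > 32500 nM, which is a limit of the assay and not a number. Compound 1 is therefore placed only by the limit of > 32500 nM in this assay, at which 2 of the 3 values shown sit, and nothing finer is known of it. Compound 2 `O=C(Nc1cccc(-n2cc(-c3ccncc3)c(-c3ccc(Cl)c(O)c3)n2)c1)Nc1cccc(C(F)(F)F)c1` is a urea on a related core, and in this assay compound 2 gives > 32500 nM, also a limit. Compound 3 `O=C(Nc1cccc(-n2cc(-c3ccncc3)c(-c3ccc(Cl)c(O)c3)n2)c1)Nc1ccc(Cl)c(C(F)(F)F)c1` differs from compound 2 by chloro in place of hydrogen on an aromatic carbon, and in this assay compound 3 gives 4120 nM. That step, an at least 7.8-fold lower number from compound 2 to compound 3 (0.89 log units; beyond the scatter), is the only measured one and shows a urea leaving the limit once a second halogen is present.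

Compound 4 `COc1cc(-c2nn(-c3cccc(NC(=O)Nc4ccc(Cl)c(Cl)c4)c3)cc2-c2ccncc2)ccc1Cl` is not yet measured. It differs from compound 1 by (3,4-dichlorophenyl)amino in place of 4-chloro-3-(trifluoromethyl)phenyl on a carbonyl carbon. The measured step bears on it only loosely, since compound 4 changes both the carbonyl attachment and the aryl substituents at once, while compound 1 offers no number to step from. Weighing this, compound 4 is expected to give 15000 nM, within 3000 nM to 40000 nM. That expectation corresponds to a step of an at least 2.1-fold lower number from compound 1 to compound 4 (0.33 log units; beyond the scatter).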

Compound 4, concentration for total growth inhibition: 6200 nM
Estimate against measurement, compound 4: 2.4-fold (0.38 log units) above; the measured number falls inside the stated range.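

In this assay, putting (3,4-dichlorophenyl)amino in place of 4-chloro-3-(trifluoromethyl)phenyl on the carbonyl carbon gives an at least 5.2-fold lower number from compound 1 to compound 4 (0.71 log units; beyond the scatter), a step beyond the scatter that turns the amide of compound 1 into a urea. Among these compounds, this yields the first number on the core of compound 1 and shows that a change at this carbonyl carbon can bring that core off the limit, whereas the earlier measured step concerned only a chloro on the aryl ring of a urea on a related core. Compound 1 itself remains a limit and not a number, so this step sets only a floor on the size of the change: the limit of > 32500 nM in this assay, at which 2 of the 4 values shown sit.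

The compounds shown do not separate the contribution of the new amino nitrogen from that of the changed aryl substituents, since the entering group brings both at once, and so they cannot tell whether the urea link or the second chloro accounts for the step. Also open, from the compounds shown here alone, is how this core responds to other groups at this carbonyl carbon, such as a morpholine or a carboxylic acid on the aryl ring.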